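The compounds below may be only part of what the source reports. "The series", "measured", "known", "first", "only" and "open" are said of these compounds alone.

Working notes on the series. Compound 1 `Nc1cc(N)c2nc(-c3ccccc3)c(Oc3ccc(Cl)c(Cl)c3)nc2c1` carries a 3,4-dichlorophenoxy group on the shared core. In a functional assay on NCI/ADR-RES cells (Homo sapiens) for inhibition, read by sulforhodamine B assay, with a stated time of 48 h (on this read-out lower numbers stand for higher toxicity in this test and higher numbers for lower toxicity in this test), compound 1 returns only a limit, < 100000 nM, not a number. Compound 2 `CCOC(=O)[C@H](CCC(=O)O)NC(=O)c1ccc(Oc2nc3cc(N)cc(N)c3nc2-c2ccccc2)cc1` is tested in this assay and also stops at a limit, < 100000 nM. Compound 3 `COc1ccc(CNc2nc3cc(N)cc(N)c3nc2-c2ccccc2)cc1` likewise gives only a limit in this assay, < 100000 nM. Across the three compounds the picture is therefore flat: every value sits at the limit of < 100000 nM in this assay, at which 3 of the 3 values shown sit, so no step between two measured compounds can be sized, and no compound can be set above or below another on these numbers.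

The compound still to be measured is compound 4 `Nc1cc(N)c2nc(-c3ccccc3)c(Oc3ccc(F)cc3)nc2c1`. It differs from compound 1 in one place: 4-fluorophenyl in place of 3,4-dichlorophenyl on an oxygen on an aromatic ring, that is, 4-fluorophenoxy replaces 3,4-dichlorophenoxy. With every measured compound resting at the same limit, no direction of change can be drawn from them, and the expected step from compound 1 to compound 4 in this assay is estimated as none beyond the scatter, a step that the limit leaves unreadable from compound 1 to compound 4. For compound 4 the expected value in this assay is 40000 nM, with a likely range from 8000 nM to 100000 nM, and a further limit rather than a number is considered the more probable outcome.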

Compound 4, concentration lethal to 50% of the cells: 70800 nM
The estimate for compound 4 lay 1.8-fold (0.25 log units) below the measured number, within the range that was stated.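

The change from 3,4-dichlorophenoxy to 4-fluorophenoxy between compound 1 and compound 4 yields no step that can be read in this assay, and most values shown remain limits, not numbers: the limit of < 100000 nM in this assay, at which 3 of the 4 values shown sit.

The compounds shown leave open whether any change on the shared core shifts this read-out by a size that can be stated.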